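The source may hold more compounds than are shown below. What is called first, only, known or untested is meant among the compounds shown, and "the series" means these compounds.

Measured in a functional assay on SK-OV-3 cells (Homo sapiens) for antiproliferative activity, read by MTT assay, with a stated time of 72 h; on this read-out higher numbers stand for weaker inhibition and lower numbers for stronger inhibition:

- Compound 1 `O=C(CCc1cccc2c1B(O)OC2)Nc1nccs1`: > 100000 nM (a limit of the assay)
- Compound 2 `Cc1cc(C)c(NC(=O)CCc2cccc3c2B(O)OC3)c(C)c1`: 19000 nM
- Compound 3 `O=C(CCc1cccc2c1B(O)OC2)Nc1cccc(-c2cccc(F)c2)c1`: 480 nM

The value for compound 1 is a limit and not a number, as the limit of > 100000 nM in this assay, at which 1 of the 3 values shown sits, records. Of the two true numbers in this assay, compound 2 gives 19000 nM and compound 3 gives 480 nM. Compound 3 therefore holds the lowest number, and the gap between the two lies beyond the scatter.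

Compound 4 `CSc1cccc(-c2cccc(NC(=O)CCc3cccc4c3B(O)OC4)c2)c1` has methylsulfanyl in place of fluoro on an aromatic carbon, changing 3-fluorophenyl to 3-(methylsulfanyl)phenyl. The group sits on a six-membered aromatic ring of carbon only, meta to a large group: methylsulfanyl in place of fluoro on an aromatic carbon.

For the measured compounds named here, no measured pair shows this change, so the expectation rests on compound 3 with its 480 nM. The expected step of a 1.0-fold higher number from compound 3 to compound 4 (0.02 log units; within the scatter) is none beyond the scatter, in either direction. For compound 4 the estimated value in this assay is 500 nM, with an expected range from 180 nM to 1500 nM.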

Compound 4, half-maximal inhibitory concentration: 150 nM
The estimate for compound 4 lay 3.3-fold (0.52 log units) above the measured number; measured number below the stated range.
By their numbers in this assay, from the lowest: compound 4; then compound 3; then compound 2. At a limit, above all of these: compound 1.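

In this assay, for the compounds shown here, the earlier compounds offered no step between structures differing in one place, so they said nothing about this aromatic carbon, meta to a large group, taken alone. The change from 3-fluorophenyl to 3-(methylsulfanyl)phenyl now supplies that reading, a 3.2-fold lower number from compound 3 to compound 4 (0.51 log units; beyond the scatter), which shows that the number responds to the group at this carbon and that methylsulfanyl, with its 2 heavy atoms in place of the single fluorine, goes with stronger inhibition here, although the step is modest. Nothing shown bears on the cause of this step.

The compounds shown leave open whether a methoxy group or an amine on the same aromatic carbon would follow methylsulfanyl or stay with fluoro. A single step also cannot tell whether the sulfur atom or the added carbon matters more.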